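Methylation of the Amide Nitrogen in an Arginase-1 Binding Series

This account rests on a few compounds, and the source may have more. Where it says the series, first, only, none or still open, it means among the compounds named here.

Compound 1 `Cc1cc(=O)c(O)c(C(=O)O)o1`: 8%
Compound 2 `Cc1cc(=O)c(O)c(C(N)=O)o1`: 5%

In an assay for inhibition of arginase-1 (Homo sapiens), read by scintillation counting, with a stated time of 5 min, tested at 200 uM (a lower number here means less inhibition, a higher number more inhibition at the concentration tested (going by the name of the read-out)), compound 1 gives 8% and compound 2 gives 5%. Among the measured compounds shown here, the one step measured, a number 3 percentage points lower from compound 1 to compound 2 (within the scatter), shows that replacing the hydroxy on the carbonyl carbon by amino leaves the reading within the scatter. Compound 2 thus stands at the lowest of the two numbers, though the gap to compound 1 is within the scatter and no order between them can be claimed.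

Compound 3 `CNC(=O)c1oc(C)cc(=O)c1O` differs from compound 2 by methyl in place of hydrogen on an amide-type nitrogen, that is, carbamoyl becomes methylcarbamoyl. For the measured compounds named here, only the step from compound 1 to compound 2 bears on this, and it was within the scatter; no step touching the amide-type nitrogen itself has been measured. Compound 3 is therefore expected to remain near compound 2, with an estimated step of no change at the digits printed from compound 2 to compound 3 (within the scatter), and the estimate for compound 3 is 5% with a range from -5% to 15%.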

Compound 3, a percentage reported as inhibition, at one concentration (the size of the read-out at that concentration, not a potency): 8%
Beside the measured number, compound 3's estimate is 3 percentage points below it; the range from low to high includes it.
By their numbers in this assay, from the lowest: compounds 2, 1 and 3 (each within the scatter of the next).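

In this assay, among the compounds shown here, methyl in place of hydrogen on the amide-type nitrogen gives a number 3 percentage points higher from compound 2 to compound 3 (within the scatter), the first measured step at this nitrogen, and carbamoyl and methylcarbamoyl cannot be told apart in this reading. Methylamino in place of hydroxy on a carbonyl carbon gives no change at the digits printed from compound 1 to compound 3 (within the scatter), so, like the amino of compound 2, it does not separate from the hydroxy of compound 1. No independent measurement bears on why these readings stay together.

The compounds shown leave open whether a longer chain such as ethyl, or a phenyl ring, on the amide-type nitrogen would carry the reading beyond the scatter. They also leave open whether a second methyl on that nitrogen, giving a dimethylamide, would do so.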